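From an amide side chain to an imine: paw-edema inhibition

The source may report more compounds than this note shows. Statements on the series, on what has been measured and on what is new or still open speak of the compounds shown alone.

Measured compounds:
compound 1 `N#CC1=C(NCN2CCCC2)N(c2ccccc2)C(=O)N2CCCCC(N3CCCC3)C12`: 22.9%
compound 2 `N#CC1=C(NCC(=O)N2CCCC2)N(c2ccccc2)C(=O)N2CCCCC(N3CCCC3)C12`: 40.1%
compound 3 `N#Cc1c2n(c(=O)n(-c3ccccc3)c1=N)CCCCC2N1CCCC1`: 84.6%

In a functional assay on the whole organism (strain albino) for inhibition, with Rattus norvegicus as the target, read by paw edema, with a stated time of 1 h, at a dose of 20 mmol/kg by the intraperitoneal route (a lower number here means less inhibition, a higher number more inhibition at the dose given (going by the name of the read-out)), compound 1 gives 22.9%, compound 2 gives 40.1%, and compound 3 gives 84.6%. Going by the values given here, compound 2 therefore stands second highest of the three numbers: its nearest neighbour is compound 1, the single computed step being a number 17.2 percentage points higher from compound 1 to compound 2 (beyond the scatter), and its furthest is compound 3, whose value lies well above it, though no step between these two is computed and their values are all that can be said.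

Compound 4 `COc1ccc(/C=N/C2=C(C#N)C3C(N4CCCC4)CCCCN3C(=O)N2c2ccccc2)cc1` has not yet been measured. It differs from compound 2 in one place: a group of 10 heavy atoms (8 carbon, 1 nitrogen, 1 oxygen; one six-membered aromatic ring of carbon only) in place of a group of 9 heavy atoms (6 carbon, 2 nitrogen, 1 oxygen; one five-membered non-aromatic ring with 1 hetero atom), on a double-bonded ring carbon

Among the compounds with values here, only one measured step touches the same part of the shared core, and that step was modest in size. Within the data shown here, compound 3, which carries no open side chain at all, shows the highest value, but it offers no computed step to compound 2 or compound 4. A move of some size is expected for compound 4, because a number 17.2 percentage points higher from compound 1 to compound 2 (beyond the scatter) shows that changes at this position register, yet its direction cannot be fixed from one step. Compound 4 is estimated at 50%, with a range from 25% to 75%, which means an expected step of a number 9.9 percentage points higher from compound 2 to compound 4 (within the scatter).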

Compound 4, a percentage reported as inhibition, in the whole organism at one dose (the size of the read-out at that dose, not a potency): 59.1%
Beside the measured number, compound 4's estimate is 9.1 percentage points below it, and the stated range covers the measured number.
By their numbers in this assay, from the lowest: compound 1; then compound 2; then compound 4; then compound 3.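

The result shows that this position on the double-bonded ring carbon does not depend on the amide side chain to register in this assay: the entering group, with a six-membered aromatic ring of carbon only and 0 hydrogen-bond donors, replaces (((pyrrolidin-1-yl)carbonyl)methyl)amino and gives a number 19 percentage points higher from compound 2 to compound 4 (beyond the scatter). Set against the side chain ending in pyrrolidin-1-yl, the same group gives the largest step of the series, a number 36.2 percentage points higher from compound 1 to compound 4 (beyond the scatter), so the value at this position has now moved by a large amount with the core unchanged. No measurement shown here explains either step.

The compounds shown leave open which part of the entering group goes with the rise, the aromatic ring, its methoxy group or the double bond to nitrogen, as these all enter together. From the compounds shown here alone, it also remains open how a carboxylic acid or a chlorine in place of the methoxy group, or a simple longer alkylamine chain on this carbon, would read out, and whether any open side chain can reach compound 3 at 84.6%.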